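Anilino series on a shared core: swap at the amine nitrogen

The source may report more compounds than this note shows. Statements on the series, on what has been measured and on what is new or still open speak of the compounds shown alone.

Measured so far in a functional assay on HeLa cells (Homo sapiens) for inhibition, read by sulforhodamine B assay; on this read-out lower numbers stand for stronger inhibition and higher numbers for weaker inhibition:
compound 1 `COc1ccccc1NC1=CC(=O)c2c(nc3n2[C@H]2OC[C@@H](O)[C@H]2OC3)C1=O`: 7460 nM
compound 2 `O=C1C=C(Nc2ccccc2)C(=O)c2c1nc1n2[C@H]2OC[C@@H](O)[C@H]2OC1`: 5620 nM
compound 3 `O=C1C=C(Nc2ccc(C(F)(F)F)cc2)C(=O)c2c1nc1n2[C@H]2OC[C@@H](O)[C@H]2OC1`: > 8000 nM

Compound 1 and compound 2 sit within the usual scatter of one another in this assay, so neither can be set apart from the other. Compound 3 gives only a limit of the assay in this assay, > 8000 nM, and not a number.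

The unmeasured compound 4 `CCc1ccc(NC2=CC(=O)c3c(nc4n3[C@H]3OC[C@@H](O)[C@H]3OC4)C2=O)cc1` differs from compound 1 in one place: 4-ethylphenyl in place of 2-methoxyphenyl on an amine nitrogen. Going by the values given here, no measured step covers this exact exchange. Among the compounds with values here, the only step that changes the aryl group on the amine nitrogen is an at least 1.4-fold higher number from compound 2 to compound 3 (0.15 log units; that floor lies within the scatter), which reaches at most the floor of a limit. It suggests that substitution on that ring does not bring the number down, and it leaves open a move toward the limit.

The step of a 1.1-fold higher number from compound 1 to compound 4 (0.06 log units; within the scatter) is therefore expected to stay within the scatter or drift slightly toward weaker inhibition. For compound 4 the expected value in this assay is 8500 nM, estimated to lie between 3500 nM and 20000 nM. A limit rather than a number is a real possibility for compound 4 because the limit of > 8000 nM in this assay, at which 1 of the 3 values shown sits, already holds one of the three values.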

Compound 4, half-maximal inhibitory concentration: 6510 nM
For compound 4 the middle estimate is 1.3-fold (0.12 log units) above the measured one; the range from low to high includes it.
By their numbers in this assay, from the lowest: compounds 2, 4 and 1 (each within the scatter of the next). At a limit, above all of these: compound 3.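

In this assay, the exchange of 2-methoxyphenyl for 4-ethylphenyl on the amine nitrogen gives a 1.1-fold lower number from compound 1 to compound 4 (0.06 log units; within the scatter). Compound 4 returns a number and not a limit, so a substituent on the aryl group does not by itself lead to a limit, and removing the hydrogen-bond acceptor counted on 2-methoxyphenyl leaves no readable difference at this place. Compound 3 remains the only compound at a limit of the assay: the limit of > 8000 nM in this assay, at which 1 of the 4 values shown sits.

The exchange alters both the group and where it stands on the ring, and these compounds cannot separate the two. Also open, going by these compounds, is how an amine or a carboxylic acid on the aryl ring, or a chain longer than ethyl, would read, and whether any group on this nitrogen moves the number beyond the scatter.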